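The source may report more compounds than this note shows. Statements on the series, on what has been measured and on what is new or still open speak of the compounds shown alone.

In an ADME assay on HeLa cells (Homo sapiens) for inhibition, read by MTT assay, with a stated time of 72 h (a higher number here means a weaker inhibitor of growth, a lower number a stronger inhibitor of growth), compound 1, whose structure is `O=C(CC(=O)c1ccccc1O)c1cc2ccccc2s1`, gives 7.86 ug/mL. Compound 2, with the structure `Cc1cc(O)c(C(=O)CC(=O)c2cc3ccccc3s2)cc1Cl`, reaches the edge of what this assay can report: its result is > 100 ug/mL, a limit rather than a number. Compound 2 therefore stands at the limit of > 100 ug/mL in this assay, at which 1 of the 2 values shown sits. Compound 3, with the structure `Cc1ccc(C(=O)CC(=O)c2cc3ccccc3s2)c(O)c1`, has not been measured; it differs from compound 2 by hydrogen in place of chloro on an aromatic carbon. Among the compounds with values here, no step between two measured compounds is available, so any expectation rests only on what compounds 1 and 2 show. The step of an at least 2.5-fold lower number from compound 2 to compound 3 (0.39 log units; beyond the scatter) is expected to point toward stronger growth inhibition than the limit reached by compound 2, though with wide uncertainty. For compound 3 the estimated result is 40 ug/mL, expected to fall between 10 ug/mL and 100 ug/mL.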

Compound 3, concentration for 50% growth inhibition: 23.1 ug/mL
For compound 3 the middle estimate is 1.7-fold (0.24 log units) above the measured one; low and high end bracket the measured number.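

In this assay, hydrogen in place of chloro on the aromatic carbon para to a hydroxy group gives an at least 4.3-fold lower number from compound 2 to compound 3 (0.63 log units; beyond the scatter), which shows that this one position can decide whether any measurable growth inhibition appears. Compound 2 has only a limit and not a number, so that step gives a minimum size and not an exact one: the limit of > 100 ug/mL in this assay, at which 1 of the 3 values shown sits. The methyl group also matters, though modestly: methyl in place of hydrogen on an aromatic carbon gives a 2.9-fold higher number from compound 1 to compound 3 (0.47 log units; beyond the scatter).

The compounds shown do not tell whether chloro would have the same effect without the methyl group, as compound 2 carries both. Going by these compounds, how a fluoro, a methoxy or an amine on this same carbon would compare with hydrogen and chloro also remains open.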